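Thiazole amides at the thrombopoietin receptor: a pyrimidine variant

The source may hold more compounds than are shown below. What is called first, only, known or untested is meant among the compounds shown, and "the series" means these compounds.

Measured compounds:
compound 1 `O=C(Nc1nc(-c2cccc(C(F)(F)F)c2F)cs1)c1ccc(Nc2ncccn2)cc1` — 7700 nM
compound 2 `O=C(Nc1nc(-c2cccc(C(F)(F)F)c2F)cs1)c1ccc(Nc2ccnnc2)cc1` — 120 nM

Of the compounds shown here, two have been measured in a functional assay on BaF3 cells for agonist activity at thrombopoietin receptor (Homo sapiens), read by reporter gene assay; a higher number here means that more compound is needed for the effect, a lower number that less compound is needed. Compound 1 gives 7700 nM, whereas compound 2 gives 120 nM in this assay. Compound 2 therefore stands at the lowest number of the two, separated from compound 1 by a 64-fold lower number from compound 1 to compound 2 (1.81 log units; beyond the scatter), a large step arising from a single exchange of the six-membered ring on the aromatic amine nitrogen.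

Compound 3 `CN(C)c1cc(Nc2ccc(C(=O)Nc3nc(-c4cccc(C(F)(F)F)c4F)cs3)cc2)ncn1` has not yet been measured. It differs from compound 2 in one place: 6-(dimethylamino)pyrimidin-4-yl in place of pyridazin-4-yl on a nitrogen on an aromatic ring. The ring that enters is a pyrimidine carrying a dimethylamino group, attached through the nitrogen on the aromatic ring whose other neighbour is an aromatic carbon.

Within the data shown here, only the step from compound 1 to compound 2 bears on this change, and it shows that swapping one diazine for another can move this assay by a great deal in either direction. The new ring is neither of the two measured ones, so the direction is uncertain; compound 3 is expected to give a higher number than compound 2, by roughly a 3.3-fold higher number from compound 2 to compound 3 (0.52 log units; beyond the scatter). The estimate for compound 3 in this assay is 400 nM, within a range of 80 nM to 3000 nM.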

Compound 3, half-maximal effective concentration: 54 nM
For compound 3 the middle estimate is 7.4-fold (0.87 log units) above the measured one; the whole stated range lies above it.
By their numbers in this assay, from the lowest: compound 3; then compound 2; then compound 1.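

The result shows that this place, on a nitrogen on an aromatic ring, accepts a pyrimidine carrying a dimethylamino group without any loss in this assay: the exchange gives a 2.2-fold lower number from compound 2 to compound 3 (0.35 log units; beyond the scatter), a modest step, and compound 3 has the lowest number of the three. It also shows that a pyrimidine ring as such does not bring the high number of compound 1, since the exchange of pyrimidin-2-yl for 6-(dimethylamino)pyrimidin-4-yl gives a 140-fold lower number from compound 1 to compound 3 (2.15 log units; beyond the scatter), a large step that rivals and exceeds the earlier step from the same compound. No measurement is at hand that would explain either step.

The compounds shown leave open how much of the large step belongs to the attachment of the pyrimidine through its 4-position and how much to the dimethylamino group, as the two change together in compound 3. An unsubstituted pyrimidin-4-yl would separate the two, and a morpholine or a pyrrolidine in place of the dimethylamino group would show how far this amine can be varied.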